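The compounds below may be only part of what the source reports. "The series", "measured", "known", "first", "only" and "open" are said of these compounds alone.

Measured so far:

compound 1, `CCSCCC12CCC(c3nnc(-c4ccccc4C(F)(F)F)n3C)(CC1)CC2` — in an assay on CHO-K1 cells for inhibition of 11-beta-hydroxysteroid dehydrogenase type 2 (Homo sapiens), read by scintillation proximity assay (on this read-out lower numbers stand for stronger inhibition and higher numbers for weaker inhibition), compound 1 gives > 4000 nM, a limit of the assay.
compound 2, `Cn1c(-c2ccccc2C(F)(F)F)nnc1C12CCC(CCS(C)(=O)=O)(CC1)CC2` — in this assay compound 2 gives > 4000 nM, a limit of the assay.
compound 3, `CCS(=O)(=O)CCC12CCC(c3nnc(-c4ccccc4C)n3C)(CC1)CC2` — in this assay compound 3 gives > 4000 nM, a limit of the assay.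

Compound 2 stands at the limit of > 4000 nM in this assay, at which 3 of the 3 values shown sit, as do the two other values shown, so no ordering among the three can be read. Among the compounds with values here, the single one-place step among them, a step that the two limits leave unreadable from compound 1 to compound 2, is unreadable for the same reason.

Compound 4, `Cn1c(-c2ccccc2C(F)(F)F)nnc1C12CCC(CNS(C)(=O)=O)(CC1)CC2`, is not yet measured in this assay. It differs from compound 2 by methanesulfonamido in place of (methylsulfonyl)methyl on a saturated chain carbon bound to a saturated ring carbon. Within the data shown here, no measured step bears readably on this change: the only comparable step, from compound 1 to compound 2, is hidden by the two limits, and the three measured values give no foothold for a direction or size. With the shared core and the aryl-triazole part of compound 2 kept, the expectation for compound 4 is a result again at or beyond the limit, with an expected step that the limit leaves unreadable from compound 2 to compound 4 of no readable size. Compound 4 is therefore estimated at 6000 nM, with a range from 2000 nM to 20000 nM, most probably reported only as a limit.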

Compound 4, half-maximal inhibitory concentration: > 4000 nM
Compound 4 gave a limit, no number; the forecaster's own chance of this, stated with the estimate: 80%; the middle value does not contradict the limit.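

In this assay compound 4 gives > 4000 nM, a limit of the assay and not a number. No step from compound 1 or compound 2 to compound 4 can be read: the limit of > 4000 nM in this assay, at which 4 of the 4 values shown sit.

The compounds shown leave open how strongly any of the four inhibits, and whether methanesulfonamido and (methylsulfonyl)methyl differ at all on this read-out.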